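Swapping Methoxy for Methyl on a Glycine Transporter Inhibitor

The compounds below may be only part of what the source reports. "The series", "measured", "known", "first", "only" and "open" are said of these compounds alone.

Compound 1: `CCN1CCCC(NC(=O)c2c(OC)cc(C(F)(F)F)cc2C(F)(F)F)(c2ccccc2)C1` gives 230 nM
Compound 2: `COc1cc(C(F)(F)F)ccc1C(=O)NC1(c2ccccc2)CCCN(C)C1` gives 4800 nM

In an assay on cells for inhibition of sodium- and chloride-dependent glycine transporter 1 (Homo sapiens) (a higher number here means that more compound is needed for the effect, a lower number that less compound is needed), compound 2 gives 4800 nM, the higher of the two numbers; compound 1 gives 230 nM, a gap well beyond the usual scatter. Compound 3 `Cc1cc(C(F)(F)F)ccc1C(=O)NC1(c2ccccc2)CCCN(C)C1` differs from compound 2 in one place: methyl in place of methoxy on an aromatic carbon. Among the compounds with values here, no measured pair shows this change, and both measured compounds carry the methoxy, so there is no direct guide. A modest shift is expected, most likely toward a somewhat higher number in this assay, though one within or only slightly beyond the scatter remains plausible. Compound 3 is expected to give 7000 nM, within 2500 nM to 20000 nM, an expected step of a 1.5-fold higher number from compound 2 to compound 3 (0.16 log units; within the scatter).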

Compound 3, half-maximal effective concentration: 320 nM
Compound 3: the middle estimate sits 22-fold (1.34 log units) above what was measured, outside the stated range (below it).
By their numbers in this assay, from the lowest: compounds 1 and 3 (each within the scatter of the next); then compound 2.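

In this assay, methyl in place of methoxy on this aromatic carbon gives a 15-fold lower number from compound 2 to compound 3 (1.18 log units; beyond the scatter), so the group at this position matters greatly. Both earlier compounds carried methoxy here, so they could not show this. Nothing measured here explains the step.

Still open, as far as these compounds go, is how other groups on this carbon, such as a chlorine atom or a nitrile, would compare with methyl. Also open, from the compounds shown here alone, is whether the same swap would give a step of similar size on the core of compound 1.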